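This account rests on a few compounds, and the source may have more. Where it says the series, first, only, none or still open, it means among the compounds named here.

Working notes on the series. In an ADME assay on L1210/0 cells (Mus musculus) for cytotoxicity, with a stated time of 48 h (a lower number here means a stronger inhibitor, a higher number a weaker inhibitor), compound 1 `CC(=O)OCCOCn1cnc2c(S)nc(F)nc21` gives 40000 nM, and compound 2 `[N-]=[N+]=NCc1cn([C@H]2C[C@H](O)[C@@H](CO)O2)c(=O)[nH]c1=O` gives 124000 nM. Compound 2 stands at the highest of the two numbers in this assay; compound 1 gives the lower number, and the gap between the two lies beyond the scatter. Compound 3 `O=c1[nH]c(=O)n([C@H]2C[C@H](O)[C@@H](CO)O2)cc1C1SCCS1` differs from compound 2 in one place: a group of 5 heavy atoms (3 carbon, 2 sulfur; one five-membered non-aromatic ring with 2 hetero atoms) in place of a group of 4 heavy atoms (1 carbon, 3 nitrogen; no ring), on an aromatic carbon. Within the data shown here, no step between two measured compounds matches this change, so nothing measured sets its size. The step from a 1.2-fold lower number from compound 2 to compound 3 (0.09 log units; within the scatter) is expected to be none beyond the scatter. Compound 3 is estimated at 100000 nM in this assay, with a range from 20000 nM to 500000 nM.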

Compound 3, half-maximal inhibitory concentration: > 200000 nM
Compound 3: only a limit was reported; the forecaster's own chance of this, stated with the estimate: 30%; at least 2.0-fold (0.30 log units) between middle value and limit.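

In this assay compound 3 gives > 200000 nM, which is a limit and not a number. Exchanging azidomethyl for the five-membered non-aromatic ring with 2 hetero atoms on this aromatic carbon gives an at least 1.6-fold higher number from compound 2 to compound 3 (0.20 log units; that floor lies within the scatter). Among these compounds, this is the first reading at this position: the change brings no lower number, and the true size of the step remains unset.

On these data alone, how far the true value of compound 3 lies past its limit stays open. Also open, as far as these compounds go, is whether an amine or a carboxylic acid on this aromatic carbon would give a lower number.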